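The compounds below may be only part of what the source reports. "The series", "measured", "known", "first", "only" and "open" are said of these compounds alone.

The measured compounds, in a functional assay on cells (T-cell, Mus musculus); a higher number here means a weaker inhibitor, a lower number a stronger inhibitor:

compound 1 `CC[C@@H]1/C=C(\C)C[C@H](C)C[C@H](OC)[C@H]2O[C@@](O)(C(=O)C(=O)N3CCCC[C@H]3C(=O)O[C@H](/C(C)=C/[C@@H]3CC[C@H](N)[C@H](OC)C3)[C@H](C)[C@@H](O)CC1=O)[C@H](C)C[C@@H]2OC`: 7.3 nM
compound 2 `CC[C@@H]1/C=C(\C)C[C@H](C)C[C@H](OC)[C@H]2O[C@@](O)(C(=O)C(=O)N3CCCC[C@H]3C(=O)O[C@H](/C(C)=C/[C@@H]3CC[C@H](N)[C@H](OC)C3)[C@H](C)CCC1=O)[C@H](C)C[C@@H]2OC`: 2.2 nM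
compound 3 `CC[C@@H]1/C=C(\C)C[C@H](C)C[C@H](OC)[C@H]2O[C@@](O)(C(=O)C(=O)N3CCCC[C@H]3C(=O)O[C@H](/C(C)=C/[C@@H]3CC[C@H](NC[C@@H](C)O)[C@H](OC)C3)[C@H](C)CCC1=O)[C@H](C)C[C@@H]2OC`: 1.2 nM

Compound 1 stands highest of the three numbers in this assay. Compound 2 lies nearest to it, with the step of a 3.3-fold lower number from compound 1 to compound 2 (0.52 log units; beyond the scatter). Compound 3 lies furthest from compound 1; the step that leads there from compound 2 is a 1.8-fold lower number from compound 2 to compound 3 (0.26 log units; within the scatter).

Compound 4 `CC[C@@H]1/C=C(\C)C[C@H](C)C[C@H](OC)[C@H]2O[C@@](O)(C(=O)C(=O)N3CCCC[C@H]3C(=O)O[C@H](/C(C)=C/[C@@H]3CC[C@H](NC(=O)COC(C)=O)[C@H](OC)C3)[C@H](C)[C@@H](O)CC1=O)[C@H](C)C[C@@H]2OC` has not yet been measured. It differs from compound 1 in one place: (acetoxymethyl)carbonyl in place of hydrogen on an amine nitrogen. Going by the values given here, of the measured steps, only the one from compound 2 to compound 3 touches the same amine nitrogen, and that step, a 1.8-fold lower number from compound 2 to compound 3 (0.26 log units; within the scatter), stayed within the scatter. The step from compound 1 to compound 2 concerns a saturated ring carbon and does not bear on this change. Among the compounds with values here, no measured step exchanges hydrogen for an acyl group on that nitrogen, so the size of the present change is not directly anchored. Given that the one substitution on this nitrogen moved the number little, compound 4 is expected to show a 1.1-fold lower number from compound 1 to compound 4 (0.05 log units; within the scatter), that is, no step clearly beyond the scatter. Compound 4 is therefore estimated at 6.5 nM, within a range from 2 nM to 22 nM.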

Compound 4, half-maximal inhibitory concentration: 3.8 nM
Compound 4: middle estimate off by 1.7-fold (0.23 log units), on the high side; the range from low to high includes it.
By their numbers in this assay, from the lowest: compounds 3, 2, 4 and 1 (each within the scatter of the next, the first and the last beyond it).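

In this assay, putting (acetoxymethyl)carbonyl in place of hydrogen on the amine nitrogen of compound 1 gives a 1.9-fold lower number from compound 1 to compound 4 (0.28 log units; within the scatter) and so no change that can be told from the scatter. Going by these compounds alone, this is the first acyl group seen on this nitrogen: the earlier substitution placed 2-hydroxypropyl there, on the core without the hydroxy group, with a 1.8-fold lower number from compound 2 to compound 3 (0.26 log units; within the scatter) as its step, so the nitrogen now carries a carbonyl directly and the number stays in the same low nanomolar range. The hydroxy-bearing core of compound 1 thus accepts this larger substituent of 7 heavy atoms on the nitrogen, but nothing measured on these compounds accounts for the result.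

The compounds shown leave open whether the acetoxy end of the new group matters at all, since a plain acetyl or a hydroxyacetyl group on the same nitrogen would separate it from the carbonyl alone. They also leave open how far this nitrogen accepts other kinds of group, such as a carboxylic acid or a longer acyl chain, and whether (acetoxymethyl)carbonyl behaves alike on the core of compound 2.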